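The source may report more compounds than this note shows. Statements on the series, on what has been measured and on what is new or still open speak of the compounds shown alone.

Measured compounds:
Compound 2, `CCCCCOC(=O)N1CCN(C(=O)[C@H](CCC(=O)O)NC(=O)c2cc(N3CCC(C(=O)N4CCCC4)CC3)nc(-c3ccccc3)n2)CC1`, in an in vivo ADME assay on the whole organism (strain Sprague-Dawley) for pharmacokinetics, with Rattus norvegicus as the target (on this read-out lower numbers stand for narrower distribution and higher numbers for wider distribution into tissues), compound 2 gives 0.2 L/kg.
Compound 1, `CCCCCOC(=O)N1CCN(C(=O)[C@H](CCC(=O)O)NC(=O)c2cc(N3CCC(C(=O)N(CC)CC)CC3)nc(-c3ccccc3)n2)CC1`, in this assay compound 1 gives 0.21 L/kg.

Among the measured compounds shown here, compound 2 stands at the lower of the two numbers so far, with compound 1 as its only neighbour; the step of a 1.1-fold lower number from compound 1 to compound 2 (0.02 log units; within the scatter) lies within the scatter, so the two values cannot be told apart.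

Compound 3, `CCCCCOC(=O)N1CCN(C(=O)[C@H](CCC(=O)O)NC(=O)c2cc(N3CCC(C(N)=O)CC3)nc(-c3ccccc3)n2)CC1`, differs from compound 2 by amino in place of pyrrolidin-1-yl on a carbonyl carbon. For the measured compounds named here, the only measured step that bears on this is the one from compound 1 to compound 2, which also exchanged the group on that carbonyl carbon and gave a 1.1-fold lower number from compound 1 to compound 2 (0.02 log units; within the scatter), a change that stayed within the scatter. Going by the values given here, there is no measured compound carrying the smaller amino group, so its effect is not known from these data.

On that basis no step beyond the scatter is expected from compound 2 to compound 3, and the step is estimated as no change at the digits printed from compound 2 to compound 3 (within the scatter). For compound 3 the expected value in this assay is 0.2 L/kg, with a range from 0.12 L/kg to 0.35 L/kg.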

Compound 3, volume of distribution at steady state: 2.4 L/kg
For compound 3 the middle estimate is 12-fold (1.08 log units) below the measured one; the whole stated range lies below it.
By their numbers in this assay, from the lowest: compounds 2 and 1 (each within the scatter of the next); then compound 3.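

In this assay the group on the carbonyl carbon proves able to move the number a long way, since amino in place of pyrrolidin-1-yl gives a 12-fold higher number from compound 2 to compound 3 (1.08 log units; beyond the scatter) and amino in place of diethylamino gives an 11-fold higher number from compound 1 to compound 3 (1.06 log units; beyond the scatter) in the same direction. The earlier exchange between the two larger groups gave only a 1.1-fold lower number from compound 1 to compound 2 (0.02 log units; within the scatter) and so showed no sensitivity at this position, which means the quiet result held for that pair alone and not for the position as a whole. What sets compound 3 apart from both compound 1 and compound 2 is a single change at this place, a carbamoyl with one heavy atom on the carbonyl carbon and one hydrogen-bond donor counted on amino, but no measurement shown here explains the jump.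

The compounds shown cannot separate the gain of that donor from the loss of the carbon atoms, and a methylamino or dimethylamino group on the same carbonyl carbon would bear directly on that question. As far as these compounds go, it also remains open whether a carboxylic acid at this place, or a longer chain on the amide nitrogen, would fall with compound 3 or with compound 1 and compound 2.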